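Swapping the pyridine for a pyrrole on the amide

A few compounds are considered here, and "the series" means these few. Any claim that something is new, unique, unknown or untested is made for them only; others in the source may bear on it.

Compound 1 `CCc1ccc(C(=O)Nc2ccc3nc(N4CCN(CC)CC4)cc(C)c3c2)cc1` gives 9850 nM in a functional assay on SK-BR-3 cells (Homo sapiens) for antiproliferative activity, read by MTT assay, with a stated time of 72 h; a higher number here means a weaker inhibitor, a lower number a stronger inhibitor.
Compound 2 `CCN1CCN(c2cc(C)c3cc(NC(=O)c4cc(Cl)cc(Cl)c4)ccc3n2)CC1` gives 2660 nM in this assay.
Compound 3 `CCN1CCN(c2cc(C)c3cc(NC(=O)c4cccnc4)ccc3n2)CC1` gives 10600 nM in this assay.

Compound 3 has the highest number of the three. The step of a 1.1-fold higher number from compound 1 to compound 3 (0.03 log units; within the scatter) lies within the scatter, whereas a 4.0-fold higher number from compound 2 to compound 3 (0.60 log units; beyond the scatter) is a modest rise. Compound 4 `CCN1CCN(c2cc(C)c3cc(NC(=O)c4ccc[nH]4)ccc3n2)CC1` differs from compound 3 by 1H-pyrrol-2-yl in place of pyridin-3-yl on a carbonyl carbon. Going by the values given here, no measured step exchanges one ring heteroaryl for a five-membered one; the steps seen so far swap substituted phenyl groups for the pyridine and range from within the scatter to modest. Compound 4 is therefore expected to stay close to compound 3, with an estimated step of a 1.2-fold lower number from compound 3 to compound 4 (0.07 log units; within the scatter) in this assay. Compound 4 is estimated at 9000 nM, expected between 3000 nM and 30000 nM.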

Compound 4, half-maximal inhibitory concentration: 13200 nM
Compound 4: the middle estimate sits 1.5-fold (0.17 log units) below what was measured; low and high end bracket the measured number.
By their numbers in this assay, from the lowest: compound 2; then compounds 1, 3 and 4 (each within the scatter of the next).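

At this carbonyl carbon, the five-membered 1H-pyrrol-2-yl ring, with its hydrogen-bond donor, reads the same as the six-membered pyridin-3-yl ring (a 1.2-fold higher number from compound 3 to compound 4 (0.10 log units; within the scatter)) and the 4-ethylphenyl group (a 1.3-fold higher number from compound 1 to compound 4 (0.13 log units; within the scatter)) in this assay. Only the 3,5-dichlorophenyl group stands apart (a 5.0-fold higher number from compound 2 to compound 4 (0.70 log units; beyond the scatter)), so this ring swap gives no readable gain or loss. Nothing measured here explains these numbers.

From the compounds shown here alone, whether compound 2 needs both chlorine atoms remains open. So does how a single chlorine or a carboxylic acid on the phenyl ring would read.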